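A few compounds are considered here, and "the series" means these few. Any claim that something is new, unique, unknown or untested is made for them only; others in the source may bear on it.

Compound 1 `CCc1nc(C(=O)OC)nn1-c1ccc(F)cc1`: 11000 nM in a functional assay on Jurkat cells (Homo sapiens) for inhibition, read by MTT assay, with a stated time of 72 h; on this read-out higher numbers stand for weaker inhibition of growth and lower numbers for stronger inhibition of growth
Compound 2 `COC(=O)c1nc(C2CCCCC2)n(-c2ccc(F)cc2)n1`: > 100000 nM

For compound 2 this is only a limit of the assay, (the limit of > 100000 nM in this assay, at which 1 of the 2 values shown sits), so no number is known for it. Going by the values given here, the single measured step, an at least 9.0-fold higher number from compound 1 to compound 2 (0.95 log units; beyond the scatter), came from cyclohexyl in place of ethyl on an aromatic carbon. Compound 3 `COC(=O)c1nc(-c2ccsc2)n(-c2ccc(F)cc2)n1` differs from compound 2 by thiophen-3-yl in place of cyclohexyl on an aromatic carbon. Among the compounds with values here, no measured step covers this change, and the only step touching compound 2 ends at a limit, so its bearing is indirect. The expected step is an at least 2.0-fold lower number from compound 2 to compound 3 (0.30 log units; that floor lies within the scatter), toward stronger growth inhibition. Compound 3 is estimated at 50000 nM, within 10000 nM to 200000 nM.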

Compound 3, concentration for 50% growth inhibition: 54000 nM
Compound 3: the middle estimate sits 1.1-fold (0.03 log units) below what was measured; low and high end bracket the measured number.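

Thiophen-3-yl on this aromatic carbon, between two ring nitrogen atoms, gives a number that can be read in this assay, so a ring here does not by itself end at the limit. Ethyl still gives stronger growth inhibition, with a 4.9-fold higher number from compound 1 to compound 3 (0.69 log units; beyond the scatter). Against cyclohexyl the change shows an at least 1.8-fold lower number from compound 2 to compound 3 (0.26 log units; that floor lies within the scatter), which is only a floor, since compound 2 is a limit and not a number: the limit of > 100000 nM in this assay, at which 1 of the 3 values shown sits.

The compounds shown leave open whether phenyl or a longer chain such as propyl on this carbon would read closer to ethyl or to thiophen-3-yl. They also leave open what a carboxylic acid in place of the methoxycarbonyl group would do.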